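The source may report more compounds than this note shows. Statements on the series, on what has been measured and on what is new or still open speak of the compounds shown alone.

Four compounds share one core and are compared in a physicochemical assay for solubility, in phosphate buffer, measured as kinetic solubility, with a stated time of 1 h, at pH 7.4; a lower number here means a less soluble compound, a higher number a more soluble compound. Compound 1 `CCNC(=O)Nc1ccc(-c2nccc([C@]34CCOC[C@H]3C4)n2)cc1` gives 125 ug/mL. Compound 2 `CCNC(=O)Nc1ccc(-c2nc(C(C)(C)S(C)(=O)=O)cc([C@@]34CCOC[C@@H]3C4)n2)cc1` gives 78 ug/mL. Compound 3 `CCNC(=O)Nc1ccc(-c2nc(C(C)(C)S(C)(=O)=O)cc([C@]34CCOC[C@H]3C4)n2)cc1` gives 74 ug/mL. Compound 4 `CCNC(=O)Nc1ccc(-c2nccc([C@@]34CCOC[C@@H]3C4)n2)cc1` has not yet been measured.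

Compounds 2 and 3 are related as described by the two compounds have the same atoms and bonds and differ only in configuration as drawn: 2 of 2 stereo elements differ (all stereocentres are inverted: mirror images); a stereocentre at a saturated ring carbon is drawn R in compound 3 and S in compound 2; a stereocentre at a saturated ring carbon is drawn S in compound 3 and R in compound 2; the step of a 1.1-fold lower number from compound 2 to compound 3 (0.02 log units; within the scatter) is small, which fits because the fact that compounds 2 and 3 differ only in the configuration as drawn shows they are mirror images with the same atoms and bonds.

From compound 3 to compound 1 the change is hydrogen in place of 1-methyl-1-(methylsulfonyl)ethyl on an aromatic carbon, and it gave the step of a 1.7-fold higher number from compound 3 to compound 1 (0.23 log units; within the scatter). The change from compound 2 to compound 4 is hydrogen in place of 1-methyl-1-(methylsulfonyl)ethyl on an aromatic carbon, the same change, made on the mirror-image core.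

Because a 1.1-fold lower number from compound 2 to compound 3 (0.02 log units; within the scatter) shows that the two cores give near-identical numbers, the step of a 1.7-fold higher number from compound 3 to compound 1 (0.23 log units; within the scatter) is taken as the guide, and compound 4 is expected to show a step of a 1.7-fold higher number from compound 2 to compound 4 (0.22 log units; within the scatter) in this assay. Compound 4 is therefore estimated at 130 ug/mL, with a likely range from 70 ug/mL to 240 ug/mL.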

Compound 4, solubility: 127 ug/mL
The estimate for compound 4 lay 1.0-fold (0.01 log units) above the measured number, within the range that was stated.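

In this assay, putting hydrogen in place of 1-methyl-1-(methylsulfonyl)ethyl gives a 1.6-fold higher number from compound 2 to compound 4 (0.21 log units; within the scatter) on one core and a 1.7-fold higher number from compound 3 to compound 1 (0.23 log units; within the scatter) on its mirror image, so the change carries across these two cores with a step of much the same size. Without that group the two mirror-image cores again stay close, with a 1.0-fold higher number from compound 1 to compound 4 (0.01 log units; within the scatter), and this fits how the structures are related: the fact that compounds 1 and 4 differ only in the configuration as drawn. Both steps for the change lie within the scatter, however, so they do not show that the change itself moves the number, and a pair of mirror-image cores says nothing about how it would behave on a different core.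

The compounds shown leave open how other groups on this aromatic carbon, such as an amine, a carboxylic acid or a longer chain, would read in this assay. Also open, from the compounds shown here alone, is whether a step of this size would appear on a core that is not a mirror image of these two.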